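A few compounds are considered here, and "the series" means these few. Any claim that something is new, unique, unknown or untested is made for them only; others in the source may bear on it.

Series notes. Compound 1 `CC(C)N(Cc1cccc(OCCCCCC(=O)O)c1)C(=O)c1ccc(-c2ccco2)cc1`, compound 2 `CC(C)Oc1cccc(-c2ccc(C(=O)N(Cc3cccc(OCCCCCC(=O)O)c3)C(C)C)cc2)c1` and compound 3 `CC(C)N(Cc1cccc(OCCCCCC(=O)O)c1)C(=O)c1ccc(-c2cccc(Oc3ccccc3)c2)cc1` share one core and were tested in an ADME assay on Raji cells (Homo sapiens) for cytotoxicity, read by CellTiter-Glo and resazurin assay, with a stated time of 72 h; a higher number here means that more compound is needed for the effect, a lower number that less compound is needed. In this assay compound 1 reaches only the limit > 26000 nM. Compound 2 likewise gives only the limit > 26000 nM. Compound 3 stands at the limit > 18700 nM, so its position is a limit rather than a number. The other two values are limits as well, as the limit of > 18700 nM in this assay, at which 1 of the 3 values shown sits, and the limit of > 26000 nM in this assay, at which 2 of the 3 values shown sit, record. The steps a step that the two limits leave unreadable from compound 1 to compound 2 and a step that the two limits leave unreadable from compound 2 to compound 3 are thus unreadable in size. Compound 4 `COc1cccc(-c2ccc(C(=O)N(Cc3cccc(OCCCCCC(=O)O)c3)C(C)C)cc2)c1` differs from compound 3 by methyl in place of phenyl on an oxygen on an aromatic ring. Among the measured compounds shown here, no measured step reads on this change, so no shift beyond the scatter is expected in this assay: a step that the limit leaves unreadable from compound 3 to compound 4. For compound 4 the expected value is 26000 nM, within 10000 nM to 60000 nM.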

Compound 4, half-maximal effective concentration: > 20900 nM
Compound 4: only a limit was reported (the forecaster's own chance of this, stated with the estimate: 85%); the middle value is on the limit's open side.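

Among the compounds shown here, compound 4, like compound 1, compound 2 and compound 3, is recorded only as a limit, so no step to compound 4 can be read in size. The compounds shown leave open whether any of these changes shifts the half-maximal effective concentration in this assay.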